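This account rests on a few compounds, and the source may have more. Where it says the series, first, only, none or still open, it means among the compounds named here.

Compound 1 `COC(=O)c1ccsc1NC(=O)[C@@H]1CCCN1`: > 250 ug/mL
Compound 2 `O=C1CC[C@@H](COC(=O)c2ccsc2NC(=O)[C@@H]2CCCN2)N1`: 88.6 ug/mL

Within the data shown here, in a toxicity assay on HUVEC cells (Homo sapiens) for inhibition (on this read-out lower numbers stand for stronger inhibition of growth and higher numbers for weaker inhibition of growth), compound 2 gives 88.6 ug/mL, the only actual number so far. The value of compound 1, > 250 ug/mL, is a limit of the assay. Compound 3 `O=C(OCC(F)(F)F)c1ccsc1NC(=O)[C@@H]1CCCN1` carries trifluoromethyl in place of 5-oxopyrrolidin-2-yl on a saturated chain carbon bound to an oxygen next to a carbonyl group. Among the measured compounds shown here, the one measured step bearing on this is an at least 2.8-fold lower number from compound 1 to compound 2 (0.45 log units; beyond the scatter), where that same group replaced hydrogen. Compound 3 lacks the group, so a modest move to a higher number in this assay is expected from an at least 2.8-fold lower number from compound 1 to compound 2 (0.45 log units; beyond the scatter). The expected step is a 2.1-fold higher number from compound 2 to compound 3 (0.33 log units; beyond the scatter). The estimate for compound 3 is 190 ug/mL, with an expected range of 90 ug/mL to 250 ug/mL.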

Compound 3, concentration for 50% growth inhibition: > 250 ug/mL
Compound 3: a limit, no number (the forecaster's own chance of this, stated with the estimate: 35%); middle value at least 1.3-fold (0.11 log units) from the limit.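

Trifluoromethyl in place of 5-oxopyrrolidin-2-yl on a saturated chain carbon bound to an oxygen next to a carbonyl group gives an at least 2.8-fold higher number from compound 2 to compound 3 (0.45 log units; beyond the scatter) in this assay. Of hydrogen, 5-oxopyrrolidin-2-yl and trifluoromethyl at this place, only 5-oxopyrrolidin-2-yl gives a number rather than a limit. The step from compound 1 to compound 3 cannot be read because both compounds stand at the same limit: the limit of > 250 ug/mL in this assay, at which 2 of the 3 values shown sit.

On these data alone, whether an open-chain amide or a simple amine at this place would also give a number stays open.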